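One Chlorophenyl Swap Made Twice in a Cytotoxicity Series

The source may hold more compounds than are shown below. What is called first, only, known or untested is meant among the compounds shown, and "the series" means these compounds.

Compound 3 `O=C(CCSc1nnc(-c2ccncc2)s1)Nc1c(Cl)cccc1Cl` and compound 1 `O=C(CCSc1nnc(-c2ccncc2)s1)Nc1ccc(Cl)cc1` differ by one change: 4-chlorophenyl in place of 2,6-dichlorophenyl on an amide-type nitrogen. In an ADME assay on HepG2 cells (Homo sapiens) for cytotoxicity, with a stated time of 3 days (on this read-out lower numbers stand for higher toxicity in this test and higher numbers for lower toxicity in this test), compound 3 gives 12600 nM and compound 1 gives 7260 nM, so the change made a 1.7-fold lower number from compound 3 to compound 1 (0.24 log units; within the scatter). Compound 2 `CC(Sc1nnc(-c2ccncc2)s1)C(=O)Nc1c(Cl)cccc1Cl` is built from the same atoms as compound 3, joined differently; how the two cores differ is not broken down here. In this assay compound 2 reaches only a limit, > 50000 nM, which is the limit of > 50000 nM in this assay, at which 1 of the 3 values shown sits. Compound 4 `CC(Sc1nnc(-c2ccncc2)s1)C(=O)Nc1ccc(Cl)cc1` applies the same change to compound 2, namely (4-chlorophenyl in place of 2,6-dichlorophenyl on an amide-type nitrogen), at the same place. The step from compound 2 to compound 4 is expected to be about an at least 1.2-fold lower number from compound 2 to compound 4 (0.09 log units; that floor lies within the scatter), because the measured pair gave a 1.7-fold lower number from compound 3 to compound 1 (0.24 log units; within the scatter). Compound 4 is therefore estimated at 40000 nM in this assay, between 15000 nM and 100000 nM, with a fair chance that only a limit is reported.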

Compound 4, half-maximal cytotoxic concentration: > 50000 nM
Compound 4 gave a limit, no number; the forecaster's own chance of this, stated with the estimate: 50%; at least 1.2-fold (0.09 log units) between middle value and limit.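

No new step can be read from compound 2 to compound 4, as each gives only a limit: the limit of > 50000 nM in this assay, at which 2 of the 4 values shown sit.

The compounds shown leave open whether 4-chlorophenyl in place of 2,6-dichlorophenyl shifts the number in this assay on the core of compound 2.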